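This account rests on a few compounds, and the source may have more. Where it says the series, first, only, none or still open, it means among the compounds named here.

Working notes on the series. Compound 3 `C[C@@H](Cn1ccc(-c2ccc(C#N)c(Cl)c2)n1)NS(=O)(=O)c1cccnc1` carries a (pyridin-3-yl)sulfonyl group on the amine nitrogen of the shared core, and in a functional assay on LNCaP cells (Homo sapiens) for antiproliferative activity, read by CCK-8 assay, with a stated time of 6 days (on this read-out higher numbers stand for weaker inhibition and lower numbers for stronger inhibition), compound 3 gives 6140 nM. For the measured compounds named here, only one other number stands beside it: compound 2 `CC(Cn1ccc(-c2ccc(C#N)c(Cl)c2)n1)C(=O)Nc1cccc(C(C)O)c1` gives 4150 nM in this assay, and the two values lie within the usual scatter of each other, so compound 3 is not separated from compound 2. Compound 1 `CC(Cn1ccc(-c2ccc(C#N)c(Cl)c2)n1)C(=O)Nc1cc[nH]n1` reports only a limit, > 30000 nM, in this assay; this is the limit of > 30000 nM in this assay, at which 1 of the 3 values shown sits. Going by the values given here, the single step so far is an at least 7.2-fold lower number from compound 1 to compound 2 (0.85 log units; beyond the scatter), a change of the aryl group on an amide-type nitrogen.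

Compound 4 `C[C@@H](Cn1ccc(-c2ccc(C#N)c(Cl)c2)n1)Nc1cncnc1` differs from compound 3 by pyrimidin-5-yl in place of (pyridin-3-yl)sulfonyl on an amine nitrogen. Among the compounds with values here, the measured step from compound 1 to compound 2 concerns a different nitrogen and a different kind of exchange, so it bears on this change only loosely; no step removes a sulfonyl linker. With nothing pointing in a direction, the expectation for this assay is a change no larger than the scatter, a 1.0-fold lower number from compound 3 to compound 4 (0.01 log units; within the scatter). Compound 4 is therefore estimated at 6000 nM, within 1500 nM to 25000 nM.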

Compound 4, half-maximal inhibitory concentration: 2070 nM
Beside the measured number, compound 4's estimate is 2.9-fold (0.46 log units) above it; low and high end bracket the measured number.
By their numbers in this assay, from the lowest: compounds 4, 2 and 3 (each within the scatter of the next, the first and the last beyond it). At a limit, above all of these: compound 1.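

Pyrimidin-5-yl in place of (pyridin-3-yl)sulfonyl on an amine nitrogen gives a 3.0-fold lower number from compound 3 to compound 4 (0.47 log units; beyond the scatter) in this assay and is the first step read at this nitrogen. It shows that the sulfonyl linker can leave this position without a rise in the number, and that an aromatic ring set directly on the nitrogen is accepted here, with 6 heavy atoms entering where 9 leave. The exchange alters the linker and the ring at once, and nothing measured on either group bears on the size of this step.

Open, as far as these compounds go, is whether the lower number follows the loss of the sulfonyl or the change of ring, which pyridin-3-yl set directly on the same nitrogen would separate. Also open, from the compounds shown here alone, is how a plain phenyl or an acetyl group would read at this position.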